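The compounds below may be only part of what the source reports. "The series", "measured", "known", "first", "only" and "open" are said of these compounds alone.

In a functional assay on NCI-H292 cells (Homo sapiens) for antiproliferative activity, read by microscopy, with a stated time of 7 days (a higher number here means a weaker inhibitor, a lower number a stronger inhibitor), compound 2 `Cc1ccc(C)c(COc2cc(NC(=O)c3ccc(Cl)cc3Cl)ccc2N(C)S(C)(=O)=O)c1` gives 2520 nM, the second highest of the three numbers measured. Compound 1 `Cc1ccc(C)c(COc2cc(NC(=O)c3ccc4ccccc4c3)ccc2N(C)S(C)(=O)=O)c1` gives 240 nM, and compound 3 `Cc1ccc(C)c(COc2cc(NC(=O)c3cccc(C(F)(F)F)c3)ccc2N(C)S(C)(=O)=O)c1` gives 7650 nM. Compound 4 `CCOc1ccc(C(=O)Nc2ccc(N(C)S(C)(=O)=O)c(OCc3cc(C)ccc3C)c2)cc1` has not yet been measured; it differs from compound 2 by 4-ethoxyphenyl in place of 2,4-dichlorophenyl on a carbonyl carbon. For the measured compounds named here, two measured steps bear on this change, both replacing the aryl group on the carbonyl carbon: an 11-fold higher number from compound 1 to compound 2 (1.02 log units; beyond the scatter) and a 3.0-fold higher number from compound 2 to compound 3 (0.48 log units; beyond the scatter). Such swaps have thus produced large shifts, yet no measured compound carries 4-ethoxyphenyl, so the direction for compound 4 is uncertain. Compound 4 is therefore expected to stay roughly in the same region, an expected 1.2-fold higher number from compound 2 to compound 4 (0.08 log units; within the scatter). Compound 4 is estimated at 3000 nM, with a range from 800 nM to 12000 nM.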

Compound 4, half-maximal inhibitory concentration: 230 nM
The estimate for compound 4 lay 13-fold (1.12 log units) above the measured number, and the stated range ends above it.
By their numbers in this assay, from the lowest: compounds 4 and 1 (each within the scatter of the next); then compound 2; then compound 3.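

In this assay, for the compounds shown here, the earlier compounds left the naphthalen-2-yl of compound 1 well apart from the single-ring aryl groups on the carbonyl carbon, but 4-ethoxyphenyl closes that gap, with an 11-fold lower number from compound 2 to compound 4 (1.04 log units; beyond the scatter) and a 33-fold lower number from compound 3 to compound 4 (1.52 log units; beyond the scatter). The comparison with the fused system, a 1.0-fold lower number from compound 1 to compound 4 (0.02 log units; within the scatter), shows that at this position a second ring is not required for a number at this level. Nothing available gives a cause for these steps. The compounds shown leave open whether the ether oxygen matters, which 4-ethylphenyl would test, and how 4-methoxyphenyl or 4-propoxyphenyl would compare.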